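A few compounds are considered here, and "the series" means these few. Any claim that something is new, unique, unknown or untested is made for them only; others in the source may bear on it.

Compound 1 `C/C=C1/[C@H](O[C@@H]2O[C@H](CO)[C@@H](O)[C@H](O)[C@H]2O)OC=C(C(=O)OC)[C@H]1CC(=O)OCCc1ccccc1`: in a functional assay on SK-BR-3 cells (Homo sapiens) for antiproliferative activity, read by MTT assay, with a stated time of 72 h (a higher number here means a weaker inhibitor, a lower number a stronger inhibitor), compound 1 gives 11000 nM.
Compound 2 `C/C=C1/[C@H](O[C@@H]2O[C@H](CO)[C@@H](O)[C@H](O)[C@H]2O)OC=C(C(=O)OC)[C@H]1CC(=O)OCCCc1ccc(OC)c(OC)c1`: in this assay compound 2 gives > 20000 nM, which is a limit of the assay rather than a number.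
Compound 3 `C/C=C1/[C@H](O[C@@H]2O[C@H](CO)[C@@H](O)[C@H](O)[C@H]2O)OC=C(C(=O)OC)[C@H]1CC(=O)OCc1ccc2c(c1)OCCO2`: in this assay compound 3 gives > 15000 nM, again a limit of the assay rather than a number.

Going by the values given here, compound 3 thus stands at a limit, as does compound 2, while compound 1 is the only member of the set with a number. Compound 4 `C/C=C1/[C@H](O[C@@H]2O[C@H](CO)[C@@H](O)[C@H](O)[C@H]2O)OC=C(C(=O)OC)[C@H]1CC(=O)OCc1ccco1` differs from compound 3 by furan-2-yl in place of 2,3-dihydro-1,4-benzodioxin-6-yl on a saturated chain carbon bound to an oxygen next to a carbonyl group. The measured steps at this position, an at least 1.8-fold higher number from compound 1 to compound 2 (0.25 log units; that floor lies within the scatter), an at least 1.3-fold higher number from compound 1 to compound 3 (0.13 log units; that floor lies within the scatter) and a step that the two limits leave unreadable from compound 2 to compound 3, are either floors that lie within the scatter or unreadable, so no swap of the group here has yet produced a readable shift. Compound 4 is therefore expected to sit near the same limit, with a number no higher from compound 3 to compound 4 (the limit leaves the size open) being the expected step. The estimate for compound 4 is 15000 nM, ranging from 5000 nM to 40000 nM.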

Compound 4, half-maximal inhibitory concentration: > 15000 nM
Compound 4: no number, only a limit; the forecaster's own chance of this, stated with the estimate: 60%; the middle value lies on the limit itself.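

Compound 4 shows that a five-membered aromatic ring with one hetero atom in this place also ends at a limit rather than a number: the limit of > 15000 nM in this assay, at which 2 of the 4 values shown sit. Going by these compounds alone, the only step that can be read is an at least 1.3-fold higher number from compound 1 to compound 4 (0.13 log units; that floor lies within the scatter), so even this much reduced group cannot be told apart from the benzyl of compound 1. The steps from compound 2 and compound 3 to compound 4 cannot be read.

Going by these compounds, how far compound 2, compound 3 and compound 4 lie past their limits stays open. So does whether an amine or a carboxylic acid on this chain carbon would give a clearly lower number.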